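Swapping a furan for a thiophene on a weak inhibitor

The compounds below may be only part of what the source reports. "The series", "measured", "known", "first", "only" and "open" are said of these compounds alone.

Measured in a functional assay on K562 cells (Homo sapiens), read by MTT assay, with a stated time of 72 h; a higher number here means a weaker inhibitor, a lower number a stronger inhibitor:
Compound 1 `Nc1nc2c(c(-c3ccco3)cn2[C@@H]2O[C@H](CO)[C@@H](O)[C@H]2O)c(=O)[nH]1`: > 20000 nM, a limit of the assay and not a number
Compound 2 `Nc1nc2c(c(-c3ccoc3)cn2[C@@H]2O[C@H](CO)[C@@H](O)[C@H]2O)c(=O)[nH]1`: 19600 nM

Within the data shown here, compound 2 holds the only true number here, 19600 nM. Compound 3 `Nc1nc2c(c(-c3cccs3)cn2[C@@H]2O[C@H](CO)[C@@H](O)[C@H]2O)c(=O)[nH]1` differs from it in one group: thiophen-2-yl in place of furan-3-yl on an aromatic carbon. Among the measured compounds shown here, the only measured step that bears on this is the exchange of one furan for the other, an at least 1.0-fold lower number from compound 1 to compound 2 (0.00 log units; that floor lies within the scatter). That step involves no thiophene, so it offers only indirect guidance, and no change beyond the usual scatter is expected. The expected size of the change is an estimated 1.3-fold lower number from compound 2 to compound 3 (0.12 log units; within the scatter). A result at the limit of > 20000 nM in this assay, at which 1 of the 2 values shown sits, would be no surprise. Compound 3 is estimated at 15000 nM, with an expected range of 4000 nM to 22000 nM.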

Compound 3, half-maximal inhibitory concentration: > 20000 nM
Compound 3: only a limit was reported (the forecaster's own chance of this, stated with the estimate: 45%); middle value at least 1.3-fold (0.12 log units) away from the limit.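

In this assay, thiophen-2-yl at this position brings no lower number than furan-3-yl, with an at least 1.0-fold higher number from compound 2 to compound 3 (0.00 log units; that floor lies within the scatter). Compound 3 gives a limit of the assay and not a number, and the step between compound 1 and compound 3 cannot be read, as both values are limits. All three five-membered aromatic rings leave the compounds at or close to the end of the measurable range, and most sit at the limit itself: the limit of > 20000 nM in this assay, at which 2 of the 3 values shown sit.

On these data alone, whether a phenyl ring, an amine or a longer chain at this position would give a clearly lower number remains open.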